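Replacing a formyl group with benzimidazole on a pyrazole core

The source may report more compounds than this note shows. Statements on the series, on what has been measured and on what is new or still open speak of the compounds shown alone.

Of the compounds shown here, three have been tested in a functional assay on MCF7 cells (Homo sapiens) for antiproliferative activity, read by MTT assay, with a stated time of 48 h; on this read-out higher numbers stand for weaker inhibition and lower numbers for stronger inhibition. Compound 1, with the structure `O=Cc1cn(-c2ccccc2)nc1-c1ccc(Cl)cc1`, gives 9650 nM and stands at the highest of the three numbers. Compound 2, `Clc1cc2nc(-c3cn(-c4ccccc4)nc3-c3ccccc3)[nH]c2cc1Cl`, gives 7560 nM, a number within the usual scatter of that of compound 1. Compound 3, `Fc1ccc(-c2nn(-c3ccccc3)cc2-c2nc3cc(F)ccc3[nH]2)cc1`, gives 950 nM, which lies beyond the scatter and is the strongest inhibition seen so far.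

The new compound 4, `Clc1ccc(-c2nn(-c3ccccc3)cc2-c2nc3ccccc3[nH]2)cc1`, is reached from compound 1 by one change: 1H-benzimidazol-2-yl in place of formyl on an aromatic carbon. For the measured compounds named here, the same kind of benzimidazol-2-yl group is carried by compound 2 and compound 3, and no step between two measured compounds isolates this exchange.

In this assay compound 4 is expected to give about 2000 nM, with a likely range from 600 nM to 7000 nM. That estimate would mean a step of a 4.8-fold lower number from compound 1 to compound 4 (0.68 log units; beyond the scatter), expected to be beyond the scatter toward stronger inhibition, because compound 3 gives 950 nM while compound 1 gives 9650 nM.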

Compound 4, half-maximal inhibitory concentration: 3030 nM
Beside the measured number, compound 4's estimate is 1.5-fold (0.18 log units) below it; measured number inside the range.
By their numbers in this assay, from the lowest: compound 3; then compound 4; then compounds 2 and 1 (each within the scatter of the next).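

In this assay, swapping formyl for 1H-benzimidazol-2-yl on this aromatic carbon gives a 3.2-fold lower number from compound 1 to compound 4 (0.50 log units; beyond the scatter), a modest move toward stronger inhibition. For the compounds shown here, compound 2 and compound 3 carry the same kind of group but differ from compound 1 in more than one place, so this is the first reading of the exchange on its own, with the rest of the shared core unchanged. Nothing measured here shows why the number falls.

The compounds shown leave open whether the full two-ring group is needed at this carbon, or whether a smaller group such as a carboxylic acid or a primary amide would serve as well. They also leave open how a close relative such as benzoxazol-2-yl, which has an oxygen in the five-membered ring, would compare.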